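This account rests on a few compounds, and the source may have more. Where it says the series, first, only, none or still open, it means among the compounds named here.

Of the compounds shown here, two have numbers so far in a physicochemical assay for lipophilicity, read by HPLC, at pH 7.4; on this read-out lower numbers stand for lower lipophilicity and higher numbers for higher lipophilicity. Compound 1 (`Cc1ccc([C@@H](C)Oc2cc3onc(CCC(=O)O)c3cc2Cl)nn1`) gives 2.97, the higher of the two, and compound 2 (`C[C@@H](Oc1cc2oc(=O)n(CCC(=O)O)c2cc1Cl)c1ccc(Cl)cn1`) gives 2.65, a gap beyond the usual scatter. For the measured compounds named here, these two differ in more than one place, so no measured step isolates a single change.

Compound 3 (`C[C@@H](Oc1cc2onc(CCC(=O)O)c2cc1Cl)c1ccccn1`) has yet to be measured in this assay. It departs from compound 1 in one place, with pyridin-2-yl in place of 6-methylpyridazin-3-yl on a saturated chain carbon bound to an oxygen on an aromatic ring and a saturated chain carbon.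

Going by the values given here, with no measured step to draw on, the expectation rests on the structural change itself, anchored on compound 1 at 2.97. A moderate upward step in this assay is expected, though the data offer no direct test of that direction. The estimated step is a number 0.33 log units higher from compound 1 to compound 3 (beyond the scatter). The expected value for compound 3 is 3.3, with an estimated range from 2.9 to 3.7.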

Compound 3, distribution coefficient: 1.99
Compound 3: middle estimate off by 1.31 log units, on the high side; the measured number lies below the stated range.
By their numbers in this assay, from the lowest: compound 3; then compound 2; then compound 1.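

In this assay, the group on a saturated chain carbon bound to an oxygen on an aromatic ring and a saturated chain carbon has a clear effect on the read-out: pyridin-2-yl in place of 6-methylpyridazin-3-yl gives a number 0.98 log units lower from compound 1 to compound 3 (beyond the scatter). For the compounds shown here, this is the only single-place step available for the series, so this position is the only one with a measured change, and the direction of that change is now known for this pair alone. The data offer no measured basis for explaining the direction or the size of the step.

The change alters the ring's hetero atom count and also removes the methyl group, so this one step cannot assign the difference to either feature; an unsubstituted pyridazine and a methyl-bearing pyridine at this place would separate the two. Also open, going by these compounds, are whether the step carries over to the core of compound 2 and how a phenyl group at this place would read in this assay.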